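From Phenyl to 3,4-Dimethylphenyl on a Shared Core

The compounds below may be only part of what the source reports. "The series", "measured", "known", "first", "only" and "open" are said of these compounds alone.

Of the compounds shown here, three sharing one core have been measured so far in a functional assay on MGC-803 cells (Homo sapiens) for inhibition, read by sulforhodamine B assay (on this read-out lower numbers stand for stronger inhibition and higher numbers for weaker inhibition), and two of them return numbers. Compound 1 (`CCCc1ccc(NC2=CC(=O)c3nc4n(c3C2=O)[C@H]2OC[C@@H](O)[C@H]2OC4)cc1`) gives 1560 nM and compound 2 (`O=C1C(Nc2ccccc2)=CC(=O)c2c1nc1n2[C@H]2OC[C@@H](O)[C@H]2OC1`) gives 1830 nM so compound 2 stands within the usual scatter of compound 1. Compound 3 (`O=C1C=C(N2CCC2)C(=O)c2c1nc1n2[C@H]2OC[C@@H](O)[C@H]2OC1`) is reported only as a limit of > 16000 nM and not as a number.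

Compound 4 (`Cc1ccc(NC2=CC(=O)c3c(nc4n3[C@H]3OC[C@@H](O)[C@H]3OC4)C2=O)cc1C`) has not yet been measured. It differs from compound 2 by having 3,4-dimethylphenyl in place of phenyl on an amine nitrogen. Among the measured compounds shown here, the counted difference is 3,4-dimethylphenyl in place of phenyl on an amine nitrogen and no pair of measured compounds tests this change directly.

For the measured compounds named here, the only guide is that compound 1 at 1560 nM and compound 2 at 1830 nM lie within the scatter of each other. On that basis, no shift beyond the scatter is expected in either direction. The expected 1.2-fold lower number from compound 2 to compound 4 (0.09 log units; within the scatter) would therefore remain within the scatter of repeated measurements. For compound 4 the estimated value in this assay is 1500 nM with an expected range of 650 nM to 3800 nM and the measurement itself is still to come.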

Compound 4, half-maximal inhibitory concentration: 1050 nM
For compound 4 the middle estimate is 1.4-fold (0.15 log units) above the measured one; measured number inside the range.
By their numbers in this assay, from the lowest: compounds 4, 1 and 2 (each within the scatter of the next). At a limit, above all of these: compound 3.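

In this assay, the exchange of phenyl for 3,4-dimethylphenyl on the amine nitrogen gives a 1.7-fold lower number from compound 2 to compound 4 (0.24 log units; within the scatter), which is the first direct test of a change at this position among the compounds shown. The step shows that the two added methyl groups on the anilino ring leave the number inside the usual scatter, so this position accepts 3,4-dimethylphenyl in place of phenyl with no shift that can be told from repeat measurement, and compound 4 joins compound 1 and compound 2 as a third aryl amine that returns a number rather than a limit. Nothing measured here bears on why the change leaves the read-out where it is.

Compound 3 stays a limit of > 16000 nM in this assay and not a number, so how far it stands from the aryl amines cannot be read. On these data alone, what a methoxy group, a chlorine atom or a carboxylic acid on the phenyl ring would do at this same amine nitrogen stays open, as does a piperidine in place of the azetidine of compound 3.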